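Ring stereocentre inversion in a cyclic nitrone ester series

A few compounds are considered here, and "the series" means these few. Any claim that something is new, unique, unknown or untested is made for them only; others in the source may bear on it.

Three members of the series have a number in a physicochemical assay for lipophilicity; on this read-out lower numbers stand for lower lipophilicity and higher numbers for higher lipophilicity. Compound 1 `CCOC(=O)C1(C)C(C)CC=[N+]1[O-]` gives 1.34. Compound 2 `CCOC(=O)[C@@]1(CC)C[C@H](C)C=[N+]1[O-]` gives 1.48. Compound 3 `CCOC(=O)[C@]1(C)C[C@@H](C)C=[N+]1[O-]` gives 1.67, the highest of the three numbers; its gap to compound 2 lies within the scatter, its gap to compound 1 beyond it. Compound 4 `CCOC(=O)[C@]1(C)C[C@H](C)C=[N+]1[O-]` is not yet measured in this assay. The change from compound 3 to compound 4 is the two compounds have the same atoms and bonds and differ only in configuration as drawn: 1 of 2 stereo elements differ; a stereocentre at a saturated ring carbon is drawn R in compound 3 and S in compound 4. Going by the values given here, no pair of measured compounds shows the effect of such a change, so the expectation rests on the three values alone, which sit close together. The step from compound 3 to compound 4 is expected to be no larger than the scatter, at a number 0.12 log units lower from compound 3 to compound 4 (within the scatter). For compound 4 the estimate is 1.55, between 1.3 and 1.85.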

Compound 4, partition coefficient: 1.38
Beside the measured number, compound 4's estimate is 0.17 log units above it; the range from low to high includes it.
By their numbers in this assay, from the lowest: compounds 1, 4, 2 and 3 (each within the scatter of the next, the first and the last beyond it).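

In this assay, going by these compounds alone, the inversion gives a number 0.29 log units lower from compound 3 to compound 4 (within the scatter) for a stereocentre at a saturated ring carbon drawn R in compound 3 and S in compound 4, the first pair to isolate such a change. Since that step stays within the scatter, this pair does not show that the inversion shifts the read-out. The reading is clean in one respect: the fact that compounds 3 and 4 differ only in the configuration as drawn

Still open, going by these compounds, is what inverting the other stereo element does. Also open, on these data alone, is whether a carboxylic acid in place of the ethyl ester would leave this inversion equally small.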